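From Methoxy to Methyl on the Fused Ring

This account rests on a few compounds, and the source may have more. Where it says the series, first, only, none or still open, it means among the compounds named here.

Compound 3 `COc1ccc2nc(NC(=O)c3cn(-c4ccccc4)nc3-c3ccccc3)sc2c1` shares its core with compound 1 `O=C(Nc1nc2ccc(F)cc2s1)c1cn(-c2ccccc2)nc1-c1ccccc1` and compound 2 `O=C(Nc1nc2ccc(Cl)cc2s1)c1cn(-c2ccccc2)nc1-c1ccccc1`. In a functional assay on HT-29 cells (Homo sapiens) for cytotoxicity, read by MTT assay, with a stated time of 72 h (a higher number here means a weaker inhibitor, a lower number a stronger inhibitor), compound 1 gives 9800 nM, and compound 2 gives 7810 nM; the step of a 1.3-fold lower number from compound 1 to compound 2 (0.10 log units; within the scatter). For compound 3 the assay reports only a limit, > 50000 nM. The steps of an at least 5.1-fold higher number from compound 1 to compound 3 (0.70 log units; beyond the scatter) and an at least 6.4-fold higher number from compound 2 to compound 3 (0.80 log units; beyond the scatter) put compound 3 at the weak end of the three. Compound 4 `Cc1ccc2nc(NC(=O)c3cn(-c4ccccc4)nc3-c3ccccc3)sc2c1` differs from compound 3 by methyl in place of methoxy on an aromatic carbon. Going by the values given here, no measured step brings in a methyl, so the only guide is that introducing methoxy was what weakened compound 3; removing it is expected to move the number back, giving the step of an at least 2.5-fold lower number from compound 3 to compound 4 (0.39 log units; beyond the scatter), though the limit on compound 3 makes this uncertain. Compound 4 is estimated at 20000 nM, between 5000 nM and 60000 nM.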

Compound 4, half-maximal inhibitory concentration: > 50000 nM
Compound 4: a limit, no number (the forecaster's own chance of this, stated with the estimate: 40%); at least 2.5-fold (0.39 log units) between middle value and limit.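

Changing methoxy to methyl does not restore a measurable number at this position in this assay: compound 4 also gives only a limit, > 50000 nM. The steps of an at least 6.4-fold higher number from compound 2 to compound 4 (0.80 log units; beyond the scatter) and an at least 5.1-fold higher number from compound 1 to compound 4 (0.70 log units; beyond the scatter) show that the weak reading is not tied to methoxy alone, and among these compounds only fluoro and chloro give a number here. The step from compound 3 to compound 4 cannot be read, because both compounds stand at the same limit: the limit of > 50000 nM in this assay, at which 2 of the 4 values shown sit.

Going by these compounds, how far compound 3 and compound 4 lie beyond that limit remains open. Also open, on these data alone, is whether another group here, such as bromo, an amine or a nitrile, would give a number like those of the halogen compounds.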